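Pyridinium N-substituent and solubility in the benzothiophene ketone series

The source may hold more compounds than are shown below. What is called first, only, known or untested is meant among the compounds shown, and "the series" means these compounds.

Compound 1 `CC[n+]1ccc(CCC(=O)c2cc3cc(OC)c(OC)cc3s2)cc1` and compound 2 `COc1cc2cc(C(=O)CCc3cc[n+](CC4CCC4)cc3)sc2cc1OC` share the same core and differ only at the saturated chain carbon bound to the aromatic nitrogen. In a physicochemical assay for solubility (on this read-out lower numbers stand for lower solubility and higher numbers for higher solubility), compound 1 gives 25000 ug/mL, and compound 2 gives 6000 ug/mL. Within the data shown here, the step of a 4.2-fold lower number from compound 1 to compound 2 (0.62 log units; beyond the scatter) is the only measured step in the set, and compound 2 therefore stands at the lower of the two numbers. Compound 3 `COC(=O)c1ccc(C[n+]2ccc(CCC(=O)c3cc4cc(OC)c(OC)cc4s3)cc2)cc1` differs from compound 2 by 4-(methoxycarbonyl)phenyl in place of cyclobutyl on a saturated chain carbon bound to an aromatic nitrogen. Among the measured compounds shown here, the one step at hand, a 4.2-fold lower number from compound 1 to compound 2 (0.62 log units; beyond the scatter), shows that enlarging this substituent lowered this assay to a modest degree; the entering group here is larger again, so a further decrease beyond the scatter is expected, with a 4.0-fold lower number from compound 2 to compound 3 (0.60 log units; beyond the scatter) as the estimated step. For compound 3 the expected value in this assay is 1500 ug/mL, with a range from 400 ug/mL to 5000 ug/mL.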

Compound 3, solubility: 3500 ug/mL
Compound 3: the middle estimate sits 2.3-fold (0.37 log units) below what was measured; low and high end bracket the measured number.
By their numbers in this assay, from the lowest: compounds 3 and 2 (each within the scatter of the next); then compound 1.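

In this assay, 4-(methoxycarbonyl)phenyl in place of cyclobutyl gives a 1.7-fold lower number from compound 2 to compound 3 (0.23 log units; within the scatter) and so does not separate the two compounds, although the entering group has 10 heavy atoms against 4 and brings 2 hydrogen-bond acceptors. Against methyl, the same group gives a 7.1-fold lower number from compound 1 to compound 3 (0.85 log units; beyond the scatter), so compound 1 stands apart from both compound 2 and compound 3, and across these three compounds the read-out does not follow the heavy-atom count step by step. No supporting measurement bears on why this position behaves this way.

On these data alone, whether an amine or a carboxylic acid on the group at this position would stand apart from compound 3 in this assay remains open. So does the outcome with a longer chain in place of cyclobutyl.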